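The source may hold more compounds than are shown below. What is called first, only, known or untested is meant among the compounds shown, and "the series" means these compounds.

Of the compounds shown here, two that share one core have been measured in a functional assay on A549 cells (Homo sapiens) for inhibition, read by MTT assay, with a stated time of 72 h; a lower number here means a stronger inhibitor, a higher number a weaker inhibitor. Compound 1 `Cn1ccc2c(Oc3ccc(NC(=O)c4cn(-c5ccc(Br)cc5F)c5ccccc5c4=O)cc3F)ccnc21` gives 1520 nM. Among the measured compounds shown here, compound 2 `Cn1ccc2c(Oc3ccc(NC(=O)c4cn(-c5ccc(C(F)(F)F)cc5Cl)c5ccccc5c4=O)cc3F)ccnc21` gives 2050 nM; of the two numbers it is the one at the top, but the only measured step, a 1.3-fold higher number from compound 1 to compound 2 (0.13 log units; within the scatter), does not set the two compounds apart. Compound 3 `Cn1ccc2c(Oc3ccc(NC(=O)c4cn(-c5ccc(F)c(Cl)c5)c5ccccc5c4=O)cc3F)ccnc21` has not yet been measured. It differs from compound 2 in a single place: 3-chloro-4-fluorophenyl in place of 2-chloro-4-(trifluoromethyl)phenyl on an aromatic nitrogen. For the measured compounds named here, the one step known so far, a 1.3-fold higher number from compound 1 to compound 2 (0.13 log units; within the scatter), also exchanges the group on that aromatic nitrogen and stays within the scatter, so on this evidence a further exchange at the same place is expected to give no step beyond the scatter in this assay. For compound 3 the expected step is therefore a 1.2-fold lower number from compound 2 to compound 3 (0.08 log units; within the scatter). The estimate for compound 3 in this assay is 1700 nM, with a range from 600 nM to 4800 nM.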

Compound 3, half-maximal inhibitory concentration: 1210 nM
Compound 3: middle estimate off by 1.4-fold (0.15 log units), on the high side; the range from low to high includes it.
By their numbers in this assay, from the lowest: compounds 3, 1 and 2 (each within the scatter of the next).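

In this assay, a third phenyl group on the aromatic nitrogen again produces no step beyond the scatter: there is a 1.7-fold lower number from compound 2 to compound 3 (0.23 log units; within the scatter) and a 1.3-fold lower number from compound 1 to compound 3 (0.10 log units; within the scatter). Among the compounds shown here, the earlier pair showed this for only one exchange, whereas the three compounds now show it for three differently substituted phenyl groups, including a change from 11 heavy atoms in 2-chloro-4-(trifluoromethyl)phenyl to 8 in 3-chloro-4-fluorophenyl. No measurement here accounts for this lack of separation.

From the compounds shown here alone, all three groups are halogen-bearing phenyl rings, so it remains open whether a phenyl ring carrying an amine or a carboxylic acid, or a simple alkyl chain in place of the ring, would also stay within the scatter. Changes elsewhere on the shared core also remain open.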